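Chloro on the core of compound 3

A few compounds are considered here, and "the series" means these few. Any claim that something is new, unique, unknown or untested is made for them only; others in the source may bear on it.

In a functional assay on SW-620 cells (Homo sapiens) (on this read-out higher numbers stand for weaker inhibition of growth and lower numbers for stronger inhibition of growth), compound 1 (`O=S(=O)(/C=C/c1ccccc1)Cc1ccc(Nc2ncnc3ccccc23)cc1`) gives > 100000 nM, which is a limit of the assay and not a number. Compound 2 (`O=S(=O)(/C=C/c1ccc(F)cc1)Cc1ccc(Nc2ncnc3ccccc23)cc1`) gives 100000 nM, and compound 3 (`O=S(=O)(/C=C/c1ccc(C(F)(F)F)cc1F)Cc1ccc(Nc2ncnc3ccccc23)cc1`) gives 100000 nM, level with compound 2: no change at the digits printed from compound 2 to compound 3 (within the scatter). Compound 4 (`O=S(=O)(/C=C/c1ccc(C(F)(F)F)cc1F)Cc1ccc(Nc2ncnc3cc(Cl)ccc23)cc1`) differs from compound 3 by chloro in place of hydrogen on an aromatic carbon, turning quinazolin-4-yl into 7-chloroquinazolin-4-yl. The measured steps, a number no higher from compound 1 to compound 2 (the limit leaves the size open) and a number no higher from compound 1 to compound 3 (the limit leaves the size open), alter only the phenyl group, and the limit leaves their size open, so none of them measures this change. The expected step, a 2.5-fold lower number from compound 3 to compound 4 (0.40 log units; beyond the scatter), leans towards stronger inhibition of growth, but only loosely. Compound 4 is estimated at 40000 nM, within an expected range of 5000 nM to 100000 nM.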

Compound 4, concentration for 50% growth inhibition: > 100000 nM
Compound 4: only a limit was reported (the forecaster's own chance of this, stated with the estimate: 35%); at least 2.5-fold (0.39 log units) between middle value and limit.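

Placing chloro on the shared core, the first change shown away from the phenyl group, gives no sign of stronger inhibition of growth in this assay: a number no lower from compound 3 to compound 4 (the limit leaves the size open). The size of this step cannot be read, so the position is not yet measured, and compound 4 joins compound 1 at the limit: the limit of > 100000 nM in this assay, at which 2 of the 4 values shown sit.

On these data alone, it remains open whether another group on this aromatic carbon, such as an amine or a methoxy group, would give a readable value. As far as these compounds go, whether chloro would matter with a different phenyl group also remains open.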